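A Hydroxyethyl Replaces a tert-Butyl Group

The source may hold more compounds than are shown below. What is called first, only, known or untested is meant among the compounds shown, and "the series" means these compounds.

compound 1 `Cc1ccc(-c2cn(C/C=C3\OC(=O)C(OCc4ccccc4)=C3OCc3ccccc3)nn2)cc1`: > 100000 nM
compound 2 `CC(C)(C)c1cn(C[C@H](O)[C@H]2OC(=O)C(OCc3ccccc3)=C2OCc2ccccc2)nn1`: 28300 nM
compound 3 `COc1ccccc1-c1cn(C/C=C2\OC(=O)C(OCc3ccccc3)=C2OCc2ccccc2)nn1`: > 100000 nM

Among the measured compounds shown here, in a functional assay on HCT-116 cells (Homo sapiens) for antiproliferative activity, read by MTT assay, with a stated time of 72 h (on this read-out lower numbers stand for stronger inhibition and higher numbers for weaker inhibition), compound 2 gives 28300 nM, the only true number among the three values shown. Compound 1 reaches only a limit, > 100000 nM. Compound 3 likewise reaches only a limit, > 100000 nM. The step that the two limits leave unreadable from compound 1 to compound 3 cannot be read because both compounds sit at the limit of > 100000 nM in this assay, at which 2 of the 3 values shown sit. Compound 4 `O=C1O[C@H]([C@@H](O)Cn2cc(CCO)nn2)C(OCc2ccccc2)=C1OCc1ccccc1` differs from compound 2 by 2-hydroxyethyl in place of tert-butyl on an aromatic carbon. For the measured compounds named here, no measured step touches this part of the molecule, so the data give no size or direction for the change. Compound 4 is expected to give about 50000 nM, between 15000 nM and 150000 nM. That estimate corresponds to an expected step of a 1.8-fold higher number from compound 2 to compound 4 (0.25 log units; within the scatter), with a real chance that only a limit is reported.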

Compound 4, half-maximal inhibitory concentration: 72700 nM
The estimate for compound 4 lay 1.5-fold (0.16 log units) below the measured number, within the range that was stated.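

In this assay, among the compounds shown here, the change at this aromatic carbon gives the first readable step at this position: a 2.6-fold higher number from compound 2 to compound 4 (0.41 log units; beyond the scatter), toward weaker inhibition. Compound 4 still gives a true number and does not join the compounds at the limit: the limit of > 100000 nM in this assay, at which 2 of the 4 values shown sit. In this one pair, the position therefore takes 2-hydroxyethyl in place of tert-butyl with only a modest loss. The compounds shown leave open whether the step comes from losing the tert-butyl or from gaining the hydroxyl. They also leave open how a longer chain, an amine or a carboxylic acid would read here.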